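Open-chain amide in place of oxadiazole on the shared core

The compounds below may be only part of what the source reports. "The series", "measured", "known", "first", "only" and "open" are said of these compounds alone.

Three compounds on a shared core have numbers in an assay on HEK293 cells for inhibition of transient receptor potential cation channel subfamily M member 8 (Homo sapiens), read by FLIPR, with stated times of 5 min and 3 min; a higher number here means a weaker inhibitor, a lower number a stronger inhibitor. Compound 1 `O=C(c1sc(-c2cccc(F)c2)nc1O)N1CCOC1` gives 5500 nM. Compound 2 `Cc1nnc(-c2sc(-c3cccc(F)c3)nc2O)o1` gives 9100 nM, the highest number of the three, though compound 1 sits within the scatter of it, while compound 3 `CCON(C)C(=O)c1sc(-c2ccccc2O)nc1O` gives 1500 nM, a gap beyond the scatter. Compound 4 `CON(C)C(=O)c1sc(-c2cccc(F)c2)nc1O` is not yet measured in this assay. It differs from compound 2 by methoxy(methyl)carbamoyl in place of 5-methyl-1,3,4-oxadiazol-2-yl on an aromatic carbon. Among the measured compounds shown here, no measured pair isolates this change; compound 3 carries a related open-chain amide, but on a differently substituted core, so no clean step is available. The step from compound 2 to compound 4 is expected to be a 2.6-fold lower number from compound 2 to compound 4 (0.41 log units; beyond the scatter), a modest move toward a lower number, near the edge of the scatter. Compound 4 is estimated at 3500 nM, with a range from 1200 nM to 10000 nM.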

Compound 4, half-maximal inhibitory concentration: 96 nM
Compound 4: middle estimate off by 36-fold (1.56 log units), on the high side; measured number below the stated range.
By their numbers in this assay, from the lowest: compound 4; then compound 3; then compounds 1 and 2 (each within the scatter of the next).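

In this assay, the aromatic carbon next to the ring sulfur proves highly sensitive to the group it carries: methoxy(methyl)carbamoyl in place of 5-methyl-1,3,4-oxadiazol-2-yl gives a 95-fold lower number from compound 2 to compound 4 (1.98 log units; beyond the scatter). The carbonyl alone does not account for this, since opening the five-membered non-aromatic ring on that carbonyl gives a 57-fold lower number from compound 1 to compound 4 (1.76 log units; beyond the scatter). Nothing available explains why these steps are so large.

Still open, as far as these compounds go, is whether the oxygen on the amide nitrogen matters. A plain dimethylamino group or a longer alkoxy chain on the core of compound 4 would test this.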